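Swapping chloro for methyl on the hydroxy compound

A few compounds are considered here, and "the series" means these few. Any claim that something is new, unique, unknown or untested is made for them only; others in the source may bear on it.

Values in a functional assay on A549 cells (Homo sapiens) for antiproliferative activity, read by MTT assay, with a stated time of 72 h; a higher number here means a weaker inhibitor, a lower number a stronger inhibitor:
- compound 1 `O=C1C=C(N2CCN(c3ccccc3Cl)CC2)C(=O)c2ccccc21`: 10300 nM
- compound 2 `O=C1C=C(N2CCN(c3ccccc3Cl)CC2)C(=O)c2c(O)cccc21`: 4500 nM
- compound 3 `Cc1ccccc1N1CCN(C2=CC(=O)c3cccc(O)c3C2=O)CC1`: not yet measured

Of the two measured compounds, compound 2 holds the lower number, 4500 nM, and is therefore the stronger inhibitor in this assay. Going on to compound 3 puts methyl in place of chloro on an aromatic carbon, ortho to a large group, turning 2-chlorophenyl into 2-methylphenyl: methyl in place of chloro on an aromatic carbon. For the measured compounds named here, the only measured step is a 2.3-fold lower number from compound 1 to compound 2 (0.36 log units; beyond the scatter), a modest one that comes from hydroxy in place of hydrogen on an aromatic carbon. It leaves the 2-chlorophenyl untouched, so it gives only a rough sense of scale. No measurement covers the exchange of chloro for methyl, and no step beyond the scatter is expected in this assay. The expected step is a 1.2-fold higher number from compound 2 to compound 3 (0.09 log units; within the scatter). Compound 3 is estimated at 5500 nM, with an expected range of 2500 nM to 12000 nM.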

Compound 3, half-maximal inhibitory concentration: 5300 nM
Compound 3: the middle estimate sits 1.0-fold (0.02 log units) above what was measured, and the stated range covers the measured number.
By their numbers in this assay, from the lowest: compounds 2, 3 and 1 (each within the scatter of the next, the first and the last beyond it).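

In this assay, the exchange of chloro for methyl gives a 1.2-fold higher number from compound 2 to compound 3 (0.07 log units; within the scatter), so this read-out does not separate the two groups on this aromatic carbon, ortho to a large group. For the compounds shown here, the earlier step changed only the hydroxy site and left the 2-chlorophenyl untouched, so this is the first reading at the aryl group itself, and it shows that chloro is not required here for the level of compound 2. No measured property is available to account for this result.

Going by these compounds, what a methoxy, a trifluoromethyl or an amine would give on this aromatic carbon remains open. Also open, on these data alone, is whether the exchange of chloro for methyl reads the same on the core of compound 1, which carries no hydroxy.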